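A few compounds are considered here, and "the series" means these few. Any claim that something is new, unique, unknown or untested is made for them only; others in the source may bear on it.

Measured compounds:
compound 1 `CN(C)C12CC(N)C(C(c3ccccc3)C1)C(c1ccccc1)C2` gives 40900 nM
compound 2 `O=C(CN1CCCCC1)OC1CC2(N3CCCC3)CC(c3ccccc3)C1C(c1ccccc1)C2` gives 14200 nM
compound 3 `CN1CCN(CC(=O)NC2CC3(N(C)C)CC(c4ccccc4)C2C(c2ccccc2)C3)CC1` gives 66200 nM

These numbers come from an ADME assay on L6 cells (Rattus norvegicus) for cytotoxicity, read by resazurin assay, with a stated time of 72 h; on this read-out higher numbers stand for weaker inhibition and lower numbers for stronger inhibition. Compound 2 stands lowest of the three; compound 1 lies higher by a margin beyond the scatter, and compound 3 lies higher still. Within the data shown here, the only single-place step among them, a 1.6-fold higher number from compound 1 to compound 3 (0.21 log units; within the scatter), sits on an amine nitrogen and leaves the (((piperidin-1-yl)methyl)carbonyl)oxy group untouched, so it offers no guide to the change at hand. Compound 4 `CCN(CC)CC(=O)OC1CC2(N3CCCC3)CC(c3ccccc3)C1C(c1ccccc1)C2` differs from compound 2 by diethylamino in place of piperidin-1-yl on a saturated chain carbon bound to a carbonyl carbon. Among the measured compounds shown here, no measured step bears on this exchange, so no step beyond the scatter is expected in this assay this assay. The number for compound 4 is therefore estimated at 16000 nM, within a range from 6000 nM to 42000 nM. This amounts to an expected step of a 1.1-fold higher number from compound 2 to compound 4 (0.05 log units; within the scatter).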

Compound 4, half-maximal inhibitory concentration: 49000 nM
Estimate against measurement, compound 4: 3.1-fold (0.49 log units) below; the measured number lies above the stated range.
By their numbers in this assay, from the lowest: compound 2; then compounds 1, 4 and 3 (each within the scatter of the next).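

In this assay, among these compounds, the change at this position is not silent: diethylamino in place of piperidin-1-yl gives a 3.5-fold higher number from compound 2 to compound 4 (0.54 log units; beyond the scatter) and is the first step here to lie beyond the scatter. The number therefore responds to which amine sits on the saturated chain carbon bound to a carbonyl carbon, which the earlier step on an amine nitrogen could not show. No evidence is available to explain this difference.

Going by these compounds, it remains open whether the lower number of compound 2 depends on the ring itself or on its size. Pyrrolidin-1-yl, morpholin-4-yl or dimethylamino at this place would help to separate these possibilities.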